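A few compounds are considered here, and "the series" means these few. Any claim that something is new, unique, unknown or untested is made for them only; others in the source may bear on it.

Measured compounds:
compound 1, `Cn1ncc(Cl)c1-c1cc(C(=O)NC2CNCC2c2ccc(C(F)(F)F)cc2)oc1Cl` — 538 nM
compound 2, `Cn1ncc(Cl)c1-c1cc(C(=O)N[C@@H]2CNCC[C@H]2c2ccc(C(F)(F)F)cc2)oc1Cl` — 9.3 nM
compound 3, `Cn1ncc(Cl)c1-c1cc(C(=O)N[C@@H]2CN[C@H](CCn3cncn3)C[C@H]2c2ccc(Cl)c(Cl)c2)oc1Cl` — 4.47 nM

The three compounds share one core and were tested in an assay for inhibition of RAC-alpha serine/threonine-protein kinase (Homo sapiens), read by HTRF, with a stated time of 1 h; on this read-out lower numbers stand for stronger inhibition and higher numbers for weaker inhibition. Compound 1 gives 538 nM, compound 2 gives 9.3 nM and compound 3 gives 4.47 nM. On these numbers compound 3 stands lowest: its gap to compound 2 is beyond the scatter, and its gap to compound 1 is far larger still. Among the compounds with values here, compound 2 and compound 3 differ in more than one place, so no single step between them is defined; only their two values can be compared.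

Compound 4, `CCC[C@@H]1C[C@@H](c2ccc(Cl)c(Cl)c2)[C@H](NC(=O)c2cc(-c3c(Cl)cnn3C)c(Cl)o2)CN1`, has not yet been measured in this assay. It differs from compound 3 in one place: methyl in place of 1H-1,2,4-triazol-1-yl on a saturated chain carbon, two bonds along the chain from a saturated ring carbon. In other words, the chain that carries the triazole in compound 3 becomes a plain propyl chain in compound 4, while the rest of the molecule is unchanged. Within the data shown here, no measured pair shows this change alone, so its effect can only be guessed. Compound 4 is expected to sit close to compound 3, with a modest shift toward weaker inhibition that may not exceed the scatter, a step estimated as a 2.2-fold higher number from compound 3 to compound 4 (0.35 log units; beyond the scatter). The estimate for compound 4 in this assay is 10 nM, with a range from 3 nM to 35 nM.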

Compound 4, half-maximal inhibitory concentration: 10.4 nM
The estimate for compound 4 lay 1.0-fold (0.02 log units) below the measured number, and the stated range covers the measured number.
By their numbers in this assay, from the lowest: compound 3; then compounds 2 and 4 (each within the scatter of the next); then compound 1.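

In this assay the swap of the 2-(1H-1,2,4-triazol-1-yl)ethyl chain for propyl gives a 2.3-fold higher number from compound 3 to compound 4 (0.37 log units; beyond the scatter) in a modest step that lies beyond the usual scatter. Within the data shown here, this is the first direct reading of this position, since the earlier compounds differ from one another in more than one place: losing the triazole ring weakens inhibition measurably but only slightly, and compound 4, with a plain chain that has no ring and no hydrogen-bond acceptors, still reads (10.4 nM). So in this pair the triazole is not needed for a low number, though it does go with the lower of the two values, and no supporting measurement bears on why the number moves.

With only one replacement shown at this position, it remains open how a primary amine, a carboxylic acid, a hydroxyl group or a longer chain such as butyl would read at the same place. On these data alone, it also remains open whether the same swap would give a step of similar size with other groups elsewhere on the shared core.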